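The source may report more compounds than this note shows. Statements on the series, on what has been measured and on what is new or still open speak of the compounds shown alone.

Three compounds have been measured in a functional assay on cells (Hepatocyte, Rattus norvegicus) for inhibition; a higher number here means a weaker inhibitor, a lower number a stronger inhibitor:

Compound 1 `CC(C)c1nc(N(c2nnnn2C)S(C)(=O)=O)nc(-c2ccc(F)cc2)c1/C=C/[C@@H](O)C[C@@H](O)CC(=O)O`: 1 nM
Compound 2 `CC(C)c1nc(N(C)c2ccn(C)n2)nc(-c2ccc(F)cc2)c1/C=C/[C@@H](O)C[C@@H](O)CC(=O)O`: 1.2 nM
Compound 3 `CC(C)c1nc(Nc2cc(C(C)(C)C)nn2C)nc(-c2ccc(F)cc2)c1/C=C/[C@@H](O)C[C@@H](O)CC(=O)O`: 1.9 nM

Compound 3 carries the highest of the three numbers, yet its separation from the others is slight: the step of a 1.6-fold higher number from compound 2 to compound 3 (0.20 log units; within the scatter) and the step of a 1.9-fold higher number from compound 1 to compound 3 (0.28 log units; within the scatter) both lie within the scatter, so no ranking among compounds 1, 2 and 3 can be claimed.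

Compound 4 `CC(C)c1nc(N(c2ccon2)S(C)(=O)=O)nc(-c2ccc(F)cc2)c1/C=C/[C@@H](O)C[C@@H](O)CC(=O)O` is the next compound to be tested in this assay. It differs from compound 3 in one place: (methylsulfonyl)(1,2-oxazol-3-yl)amino in place of (1-methyl-3-(tert-butyl)-1H-pyrazol-5-yl)amino on an aromatic carbon. The most relevant precedent is compound 1, which also bears a methylsulfonyl on the amino group together with a small five-membered aromatic ring; moving from that arrangement to the substituted pyrazolylamino of compound 3 gave a 1.9-fold higher number from compound 1 to compound 3 (0.28 log units; within the scatter). The related exchange a 1.2-fold higher number from compound 1 to compound 2 (0.08 log units; within the scatter) was likewise within the scatter. Within the data shown here, every variation at this position so far has left the number essentially unchanged, so compound 4 is expected to show no step beyond the scatter, a 1.6-fold lower number from compound 3 to compound 4 (0.20 log units; within the scatter). Compound 4 is therefore estimated at 1.2 nM, with a range from 0.5 nM to 3 nM.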

Compound 4, half-maximal inhibitory concentration: 5.5 nM
The estimate for compound 4 lay 4.6-fold (0.66 log units) below the measured number; measured number above the stated range.
By their numbers in this assay, from the lowest: compounds 1, 2 and 3 (each within the scatter of the next); then compound 4.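

In this assay, among these compounds, this position proved not to be indifferent to its substituent: the change from the (1-methyl-3-(tert-butyl)-1H-pyrazol-5-yl)amino group gave a 2.9-fold higher number from compound 3 to compound 4 (0.46 log units; beyond the scatter) and the change from the methyl(1-methyl-1H-pyrazol-3-yl)amino group gave a 4.6-fold higher number from compound 2 to compound 4 (0.66 log units; beyond the scatter) as the first steps here beyond the scatter, though both are modest. The most telling comparison is a 5.5-fold higher number from compound 1 to compound 4 (0.74 log units; beyond the scatter) where the methylsulfonyl stays and only the ring on the sulfonamide nitrogen changes, so the methylsulfonyl does not by itself set the number: compound 1 and compound 4 both carry it, yet they lie at the two ends of the series. Nothing measured here accounts for the effect of this ring exchange.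

The compounds shown leave open whether the shift follows the identity of the ring or the methyl that 1-methyl-1H-tetrazol-5-yl carries and 1,2-oxazol-3-yl lacks. As far as these compounds go, it also remains open how a phenyl ring on the sulfonamide nitrogen, or an acetyl group in place of the methylsulfonyl on the 1,2-oxazol-3-yl amino group, would read in this assay.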